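Cyano for Fluoro on the Benzyl Ring of an Aryl Ether Amide

This account rests on a few compounds, and the source may have more. Where it says the series, first, only, none or still open, it means among the compounds named here.

Measured compounds:
compound 1, `Cc1ccccc1COc1ccccc1C(=O)Nc1cccnc1`, 1500 nM
compound 2, `N#Cc1ccccc1COc1ccccc1C(=O)Nc1cccnc1`, 31800 nM
compound 3, `O=C(Nc1cccnc1)c1ccccc1OCc1cccc(F)c1`, 1600 nM

All three were tested in an assay on lysate for inhibition of phosphatidylcholine:ceramide cholinephosphotransferase 2 (Homo sapiens), read by HPLC, with stated times of 30 min and 2 h; on this read-out lower numbers stand for stronger inhibition and higher numbers for weaker inhibition. Compound 3 holds the second highest number of the three; its nearest neighbour is compound 1, at a 1.1-fold higher number from compound 1 to compound 3 (0.03 log units; within the scatter), and its furthest is compound 2, at a 20-fold lower number from compound 2 to compound 3 (1.30 log units; beyond the scatter). The unmeasured compound 4, `N#Cc1cccc(COc2ccccc2C(=O)Nc2cccnc2)c1`, differs from compound 3 in one place: cyano in place of fluoro on an aromatic carbon, on an aromatic carbon of a six-membered aromatic ring of carbon only, meta to a large group.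

Going by the values given here, one measured step bears directly on a cyano group entering this ring: a 21-fold higher number from compound 1 to compound 2 (1.33 log units; beyond the scatter), a large loss. The step of a 20-fold lower number from compound 2 to compound 3 (1.30 log units; beyond the scatter) recovers that loss when the cyano-bearing ring is exchanged. Among the compounds with values here, no measured pair shows a cyano group at the position it takes in compound 4, so the size of the effect at this place is not established, but the only evidence for cyano points toward a weaker number. Compound 4 is therefore expected to give 10000 nM, within 3000 nM to 40000 nM, a step of a 6.3-fold higher number from compound 3 to compound 4 (0.80 log units; beyond the scatter) that the measurement will confirm or correct.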

Compound 4, half-maximal inhibitory concentration: 60700 nM
Beside the measured number, compound 4's estimate is 6.1-fold (0.78 log units) below it; measured number above the stated range.
By their numbers in this assay, from the lowest: compounds 1 and 3 (each within the scatter of the next); then compounds 2 and 4 (each within the scatter of the next).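

In this assay, going by these compounds alone, cyano in place of fluoro at this place gives a 38-fold higher number from compound 3 to compound 4 (1.58 log units; beyond the scatter) and so shows directly what the earlier compounds could only suggest: the cyano group carries a large cost on a ring where fluoro is tolerated, and the cost is not confined to the 2-cyanophenyl compound. Going from 2-cyanophenyl to 3-cyanophenyl gives a 1.9-fold higher number from compound 2 to compound 4 (0.28 log units; within the scatter) and does not separate the two, so across these compounds the loss follows the cyano group and not its place, while 3-cyanophenyl in place of 2-methylphenyl gives a 40-fold higher number from compound 1 to compound 4 (1.61 log units; beyond the scatter) in line with this and none of the four goes against it. Nothing shown here accounts for the size of this loss.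

The compounds shown leave open whether the loss belongs to cyano alone or extends to other groups at this place, such as a methoxy group, a carboxylic acid or an amine. They also leave open whether a cyano group would cost as much with a different group on the amide nitrogen of the shared core.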